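Swapping one aromatic ring on a shared core

This account rests on a few compounds, and the source may have more. Where it says the series, first, only, none or still open, it means among the compounds named here.

compound 1 `NC(=O)[C@@H]1[C@H](Nc2nc(Nc3cccc(C(=O)N4CCCC4)c3)ncc2-c2ccsc2)[C@H]2C=C[C@@H]1C2` gives 110 nM
compound 2 `NC(=O)[C@@H]1[C@H](Nc2nc(Nc3cccc(C(=O)N4CCCC4)c3)ncc2-c2ccccc2)[C@H]2C=C[C@@H]1C2` gives 220 nM

Going by the values given here, both numbers come from a functional assay on THP-1 cells (Homo sapiens) for inhibition, read by ELISA, with stated times of 1 h and 18 h (on this read-out higher numbers stand for weaker inhibition and lower numbers for stronger inhibition), and compound 2 stands within the scatter of compound 1, the only other measured compound. Compound 3 `NC(=O)[C@@H]1[C@H](Nc2nc(Nc3cccc(C(=O)N4CCCC4)c3)ncc2-c2ccncc2)[C@H]2C=C[C@@H]1C2` has pyridin-4-yl in place of phenyl on an aromatic carbon, and the counted change is pyridin-4-yl in place of phenyl on an aromatic carbon in full. Among the compounds with values here, the one measured step bearing on this is a 2.0-fold higher number from compound 1 to compound 2 (0.30 log units; within the scatter) for phenyl in place of thiophen-3-yl at that carbon. Within the data shown here, no pyridin-4-yl compound has been measured, so nothing beyond the scatter is expected in this assay here. The expected step is a 1.1-fold lower number from compound 2 to compound 3 (0.04 log units; within the scatter) by this estimate. Compound 3 is estimated at 200 nM with an expected range of 70 nM to 600 nM overall.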

Compound 3, half-maximal inhibitory concentration: 320 nM
Compound 3: the middle estimate sits 1.6-fold (0.20 log units) below what was measured; the measured number falls inside the stated range.
By their numbers in this assay, from the lowest: compounds 1, 2 and 3 (each within the scatter of the next, the first and the last beyond it).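

In this assay, pyridin-4-yl in place of phenyl gives a 1.5-fold higher number from compound 2 to compound 3 (0.16 log units; within the scatter), so a ring nitrogen in this six-membered aromatic ring leaves the number within the scatter of the phenyl compound. Pyridin-4-yl in place of thiophen-3-yl gives a 2.9-fold higher number from compound 1 to compound 3 (0.46 log units; beyond the scatter), the first modest step beyond the scatter at this carbon. Nothing available bears on the reason for either step. The compounds shown leave open how a pyridin-3-yl ring, a furan-3-yl ring or an aminomethyl group on this carbon would compare with these three.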